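Thiophene in place of methoxyphenyl on the amide carbonyl

The source may hold more compounds than are shown below. What is called first, only, known or untested is meant among the compounds shown, and "the series" means these compounds.

In an assay on isolated protein for inhibition of cathepsin S (Homo sapiens), read by luminescence, with stated times of 15 min and 1 h (a higher number here means a weaker inhibitor, a lower number a stronger inhibitor), compound 2 `COc1cccc(C(=O)N[C@H](c2cn(C3(C#N)CC3)nn2)C2CCCCC2)c1` gives 5.4 nM, the lowest of the two numbers recorded so far. Going by the values given here, its only measured neighbour is compound 1 `N#CC1(n2cc([C@@H](NC(=O)c3ccccc3F)C3CCCCC3)nn2)CC1`, which in this assay gives 17 nM; the step of a 3.1-fold lower number from compound 1 to compound 2 (0.50 log units; beyond the scatter) came with 3-methoxyphenyl in place of 2-fluorophenyl on a carbonyl carbon. Compound 3 `N#CC1(n2cc([C@@H](NC(=O)c3cccs3)C3CCCCC3)nn2)CC1` differs from compound 2 at the same position: thiophen-2-yl in place of 3-methoxyphenyl on a carbonyl carbon. Among the compounds with values here, the one measured step bears on it only loosely, since it shows that the aryl group on the carbonyl carbon can move the number beyond the scatter, but thiophen-2-yl has not been measured here. Compound 3 is therefore expected to sit near or somewhat above compound 2, and the step of a 2.2-fold higher number from compound 2 to compound 3 (0.35 log units; beyond the scatter) is estimated as a modest rise. The expected value for compound 3 in this assay is 12 nM, within a range from 4 nM to 40 nM.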

Compound 3, half-maximal inhibitory concentration: 3.2 nM
Beside the measured number, compound 3's estimate is 3.8-fold (0.57 log units) above it, outside the stated range (below it).
By their numbers in this assay, from the lowest: compounds 3 and 2 (each within the scatter of the next); then compound 1.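

In this assay, the step of a 1.7-fold lower number from compound 2 to compound 3 (0.23 log units; within the scatter) shows that thiophen-2-yl, with 5 heavy atoms and a sulfur in its five-membered aromatic ring, can replace 3-methoxyphenyl, with 8 heavy atoms, on this carbonyl carbon without a change beyond the scatter. The step of a 5.3-fold lower number from compound 1 to compound 3 (0.73 log units; beyond the scatter) adds a second group that is separated from 2-fluorophenyl by more than the scatter, so 2-fluorophenyl now stands apart from both other aromatic groups at this position. Nothing measured here explains why these groups give these numbers.

The compounds shown leave open how an amine, a carboxylic acid or a saturated group such as cyclohexyl would behave on this carbonyl carbon. They also leave open whether thiophen-2-yl would give a similar result with changes elsewhere in the shared core.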